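The source may hold more compounds than are shown below. What is called first, only, known or untested is meant among the compounds shown, and "the series" means these compounds.

Measured so far:
compound 1 `O=C(Nc1ccc(Cl)cc1)Nc1cccc(NC(=O)c2ccccn2)c1`: 3620 nM
compound 2 `O=C(Nc1ccc([N+](=O)[O-])cc1)Nc1cccc(NC(=O)c2ccccn2)c1`: 320 nM
compound 3 `O=C(Nc1cccc(NC(=O)c2ccccn2)c1)Nc1ccc2ccccc2c1`: 240 nM

In a functional assay on A549 cells (Homo sapiens) for antiproliferative activity, read by MTT assay, with a stated time of 48 h (a lower number here means a stronger inhibitor, a higher number a weaker inhibitor), compound 2 gives 320 nM, the second highest of the three numbers; compound 3 gives 240 nM, within the scatter of compound 2, and compound 1 gives 3620 nM, far above it. Going by the values given here, the one measured step on this terminal ring, an 11-fold lower number from compound 1 to compound 2 (1.05 log units; beyond the scatter), shows that what sits on this ring can move the number a long way.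

Compound 4 `O=C(Nc1cccc(NC(=O)c2ccccn2)c1)NC1CCCCC1` differs from compound 2 by cyclohexyl in place of 4-nitrophenyl on an amide-type nitrogen. Among the compounds with values here, no measured step covers the loss of the aromatic ring itself; the step from compound 1 to compound 2 only shows the ring's substituent matters, and compound 3 shows an enlarged aromatic ring is tolerated. A step in this assay is therefore expected, most likely upward, with wide uncertainty. Compound 4 is estimated at 2000 nM (range 500 nM to 8000 nM), meaning an expected step of a 6.3-fold higher number from compound 2 to compound 4 (0.80 log units; beyond the scatter).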

Compound 4, half-maximal inhibitory concentration: 6260 nM
Compound 4: middle estimate off by 3.1-fold (0.50 log units), on the low side, within the range that was stated.
By their numbers in this assay, from the lowest: compounds 3 and 2 (each within the scatter of the next); then compounds 1 and 4 (each within the scatter of the next).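

In this assay, the effect of placing cyclohexyl on this amide-type nitrogen depends on the aromatic group it replaces: 4-nitrophenyl gives a 20-fold higher number from compound 2 to compound 4 (1.29 log units; beyond the scatter) and 4-chlorophenyl gives a 1.7-fold higher number from compound 1 to compound 4 (0.24 log units; within the scatter). An aromatic ring at this place is therefore not enough on its own for a low number, as 4-chlorophenyl and cyclohexyl stand within the scatter of each other. The low number of compound 2 is thus tied to the 4-nitrophenyl group as a whole and not simply to the presence of an aromatic ring.

No supporting evidence is available to explain the difference between these two steps. From the compounds shown here alone, it remains open whether an amine or a carboxylic acid in place of the nitro group would keep the low number of compound 2, and whether a nitro group on the cyclohexyl ring would restore it.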